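The compounds below may be only part of what the source reports. "The series", "measured", "known", "first", "only" and "open" are said of these compounds alone.

Measured so far:
- compound 1 `Cc1nc(SCC(=O)Nc2nc(-c3ccc(Cl)cc3)cs2)n(Nc2ccccc2)c1C`: 2650 nM
- compound 2 `Cc1ccc(Nn2c(SCC(=O)Nc3nc(-c4ccccc4)cs3)nc(C)c2C)cc1`: 17200 nM

In a functional assay on OVCAR-5 cells (Homo sapiens) for antiproliferative activity, read by sulforhodamine B assay, with a stated time of 48 h (a lower number here means a stronger inhibitor of growth, a higher number a weaker inhibitor of growth), compound 1 gives 2650 nM, the lowest of the two numbers; compound 2, which differs from it in more than one place, gives a higher number, beyond the scatter. Compound 3 `COc1ccc(Nn2c(SCC(=O)Nc3nc(-c4ccc(Cl)cc4)cs3)nc(C)c2C)cc1` has not been measured. It differs from compound 1 by methoxy in place of hydrogen on an aromatic carbon. Without a matching measured pair, only a cautious expectation is possible: compound 3 is expected to give a number close to or somewhat higher than compound 1, so a small weakening step a 1.5-fold higher number from compound 1 to compound 3 (0.18 log units; within the scatter) is estimated. Compound 3 is expected to give 4000 nM, in the range 1500 nM to 12000 nM.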

Compound 3, concentration for 50% growth inhibition: > 100000 nM
Compound 3 was reported as a limit; the forecaster's own chance of this, stated with the estimate: 10%; middle value at least 25-fold (1.39 log units) from the limit.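

Among these compounds, compounds 1 and 2 differ in more than one place, so they could not isolate any single change; this is the first one-place step, and it shows that the position on the anilino ring matters in this assay: methoxy in place of hydrogen gives an at least 37-fold higher number from compound 1 to compound 3 (1.57 log units; beyond the scatter). The value of compound 3, > 100000 nM, is a limit of the assay and not a number. The step rests on that limit: the limit of > 100000 nM in this assay, at which 1 of the 3 values shown sits.

A single group cannot show whether the loss belongs to methoxy alone or to any group at this place. From the compounds shown here alone, how a fluorine, a hydroxyl or an amine would behave there remains open.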